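The source may hold more compounds than are shown below. What is called first, only, known or untested is meant among the compounds shown, and "the series" means these compounds.

Within the data shown here, three related compounds have numbers so far in a functional assay on thoracic aorta (Rattus norvegicus, strain Wistar), with a stated time of 15 min (on this read-out lower numbers stand for an effect already at smaller amounts and higher numbers for an effect only at larger amounts of compound), and share one core. Compound 1 (`CCOc1ccc(Cl)cc1C(C)NC(=O)N(C)S(=O)(=O)c1ccccc1`) gives 10500 nM there, compound 2 (`COc1ccc(Cl)cc1C(C)NC(=O)N(C)S(=O)(=O)c1ccc(Cl)cc1`) gives 20000 nM there, and compound 3 (`CCOc1ccc(F)cc1C(C)NC(=O)N(C)S(=O)(=O)c1ccc(Cl)cc1`) gives 24500 nM there. Compound 3 thus lies within the scatter of compound 2, and its number is higher than that of compound 1 by a gap beyond the scatter. The next compound, compound 4 (`CCOc1ccc(Cl)cc1C(C)NC(=O)N(C)S(=O)(=O)c1ccc(Cl)cc1`), awaits measurement. It differs from compound 3 by chloro in place of fluoro on an aromatic carbon in a single place, with chloro in place of fluoro on an aromatic carbon para to an ethoxy group. Among the measured compounds shown here, no measured pair isolates this exchange, so the guidance is indirect. Compound 1 carries chloro on that carbon and gives 10500 nM in the same test, while compound 2 also carries chloro there and gives 20000 nM in the same test. A modest move toward a lower number is therefore expected, with a 1.6-fold lower number from compound 3 to compound 4 (0.21 log units; within the scatter) estimated to stay within the scatter of this assay when measured. For compound 4 the estimate is 15000 nM with an expected range from 6500 nM to 32000 nM in this test.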

Compound 4, half-maximal effective concentration: 14600 nM
Estimate against measurement, compound 4: 1.0-fold (0.01 log units) above; measured number inside the range.
By their numbers in this assay, from the lowest: compounds 1, 4, 2 and 3 (each within the scatter of the next, the first and the last beyond it).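

In this assay, among these compounds, chloro in place of fluoro on an aromatic carbon para to an ethoxy group gives a 1.7-fold lower number from compound 3 to compound 4 (0.22 log units; within the scatter), the first reading that isolates this exchange, and it stays within the scatter, so the two halogens are not told apart at this position. The other two single changes also stay within the scatter: methyl in place of hydrogen on the saturated chain carbon bound to the oxygen gives a 1.4-fold lower number from compound 2 to compound 4 (0.14 log units; within the scatter), and swapping a ring hydrogen for chloro gives a 1.4-fold higher number from compound 1 to compound 4 (0.14 log units; within the scatter). No single change among these four compounds therefore produces a clear shift in this assay, and no measurement at hand speaks to a cause.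

As far as these compounds go, what remains open is whether any group at this carbon can move the number beyond the scatter, for example bromo, a nitrile or an amine. The compounds shown also leave open how a carboxylic acid on the other aromatic ring would read in this assay.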